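Formyl for Methoxyphenyl on a Fused Nitrile Core

The compounds below may be only part of what the source reports. "The series", "measured", "known", "first", "only" and "open" are said of these compounds alone.

Compound 1 (`COc1ccccc1-c1c(-c2ccccc2)c(-c2ccccc2)n2ccc(C#N)cc12`) carries a 2-methoxyphenyl group on its fused core, and in an assay for inhibition of Polyunsaturated fatty acid lipoxygenase ALOX15 (Oryctolagus cuniculus) (a higher number here means a weaker inhibitor, a lower number a stronger inhibitor), compound 1 gives "not determined" (no result reported), that is, no result; compound 1 thus stands on no number here. Its nearest measured relative is compound 2 (`N#Cc1ccn2c(-c3ccccc3)c(-c3ccccc3)c(C(=O)c3ccccc3)c2c1`), which bears a benzoyl group at the same kind of position, and in this assay compound 2 gives 43000 nM, a weak inhibition. The step from compound 1 to compound 3 (`N#Cc1ccn2c(-c3ccccc3)c(-c3ccccc3)c(C=O)c2c1`) is formyl in place of 2-methoxyphenyl on an aromatic carbon. Among the compounds with values here, with no value for compound 1, no direction or size can be read for this step in this assay; what can be said is only that compound 2, the one measured member of the series, is a weak inhibitor. Because compound 2 shows 43000 nM with a carbonyl at this place, compound 3 is expected to sit in the same weak region. Compound 3 is therefore estimated at 40000 nM, within 10000 nM to 160000 nM.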

Compound 3, half-maximal inhibitory concentration: 61000 nM
For compound 3 the middle estimate is 1.5-fold (0.18 log units) below the measured one; measured number inside the range.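

In this assay the exchange of phenyl for hydrogen on the carbonyl carbon gives a 1.4-fold higher number from compound 2 to compound 3 (0.15 log units; within the scatter), so the two carbonyl compounds cannot be told apart. Compound 2 alone could not show this: at this position on an aromatic carbon of the five-membered aromatic ring, the phenyl group on the carbonyl carbon can be absent with no readable effect on the number, and inhibition stays weak with either the benzoyl group or the formyl group. None of the data given here accounts for this lack of difference.

The step from compound 1 to compound 3 still cannot be read, so these compounds say nothing about how 2-methoxyphenyl compares with formyl on this carbon, or about any group without a carbonyl there. Going by these compounds, it remains open whether an amine or a carboxylic acid at this place, or a longer chain on the carbonyl carbon, would give a number clearly apart from those of compound 2 and compound 3.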